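The source may report more compounds than this note shows. Statements on the series, on what has been measured and on what is new or still open speak of the compounds shown alone.

Working notes on the aminothiophene ketone series.

Two compounds have so far been run in a functional assay on CHO cells for agonist activity at adenosine receptor A1 (Homo sapiens), read by ERK phosphorylation, tested at 3 uM; a higher number here means a stronger effect of the compound at the concentration tested, a lower number a weaker effect. Compound 1, `Nc1sc2c(c1C(=O)c1cccc(C(F)(F)F)c1)CCC2`, gives 75% in this assay. Among the measured compounds shown here, compound 2, `Cc1ccc(C(=O)c2c(N)sc3c2CCCCCC3)cc1`, gives 56% in this assay, the lowest of the two numbers so far; compound 1 stands above it by a margin beyond the usual scatter. For the measured compounds named here, compounds 1 and 2 differ from each other in more than one place, so no single-change step can be drawn between them, and nothing more is said of that pair than what the two values show.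

The next compound to be measured is compound 3, `Nc1sc2c(c1C(=O)c1ccccc1)CCCCCC2`. It differs from compound 2 in one place only: hydrogen in place of methyl on an aromatic carbon. Going by the values given here, no measured pair in the set carries this same change, so there is no step on record to lean on. The expectation is that the step from compound 2 to compound 3 stays small, in either direction, and most likely within the scatter of repeated measurements; the estimated step is a number 1 percentage points lower from compound 2 to compound 3 (within the scatter). For compound 3 the estimated value in this assay is 55%, with a range from 35% to 75%.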

Compound 3, a percentage reported as activity, at one concentration (the size of the read-out at that concentration, not a potency): 49%
For compound 3 the middle estimate is 6 percentage points above the measured one; low and high end bracket the measured number.
By their numbers in this assay, from the lowest: compounds 3 and 2 (each within the scatter of the next); then compound 1.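

The change from 4-methylphenyl to phenyl gives the series its first single-change step in this assay and it is a number 7 percentage points lower from compound 2 to compound 3 (within the scatter) for this one pair. At this place, on an aromatic carbon para to a large group, the methyl can therefore give way to hydrogen without a shift that can be told from repeat measurement, although a single pair sets no rule for the series. Nothing on record accounts for the size of this step.

From the compounds shown here alone, what a group other than methyl or hydrogen would do at this same place stays open, whether a methoxy group, a chlorine atom, an amine or a carboxylic acid, and so does whether any of them would move the read-out beyond the scatter. Also open is whether the change from 4-methylphenyl to phenyl would read the same on the core of compound 1, since the compounds shown carry it on one core only.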